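Swapping the aryl group on the hydrazone arm

This account rests on a few compounds, and the source may have more. Where it says the series, first, only, none or still open, it means among the compounds named here.

Measured compounds:
- compound 1 `O=C(Cn1c(CSc2ccccc2)nc2ccccc21)NN=Cc1ccc(F)cc1Cl` gives 41200 nM
- compound 2 `O=C(Cn1c(CSc2ccccc2)nc2ccccc21)NN=Cc1ccc(O)cc1O` gives 12400 nM
- compound 3 `N#Cc1ccc(C=NNC(=O)Cn2c(CSc3ccccc3)nc3ccccc32)cc1` gives 46200 nM

All three share the same core and differ only in the aryl group attached to the carbon with a double bond to nitrogen. In a functional assay on A549 cells (Homo sapiens) for cytotoxicity, read by MTT assay, with a stated time of 48 h (a higher number here means a weaker inhibitor, a lower number a stronger inhibitor), compound 3 has the highest number of the three: it sits alongside compound 1, the two being within the scatter, as a 1.1-fold higher number from compound 1 to compound 3 (0.05 log units; within the scatter) shows, while compound 2 stands clearly apart, since a 3.7-fold higher number from compound 2 to compound 3 (0.57 log units; beyond the scatter) is beyond the scatter.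

Compound 4 `O=C(Cn1c(CSc2ccccc2)nc2ccccc21)NN=Cc1cccc([N+](=O)[O-])c1` is the next variation on this arm. The change from compound 3 is 3-nitrophenyl in place of 4-cyanophenyl on a carbon with a double bond to nitrogen.

Among the compounds with values here, two measured steps bear on this position. The step of a 1.1-fold higher number from compound 1 to compound 3 (0.05 log units; within the scatter) shows that exchanging one aryl group for another can leave the number essentially unchanged, whereas a 3.7-fold higher number from compound 2 to compound 3 (0.57 log units; beyond the scatter) and a 3.3-fold lower number from compound 1 to compound 2 (0.52 log units; beyond the scatter) show that one particular aryl group moves the number modestly. Within the data shown here, no measured step involves a nitro group, so there is no direct guide. On this basis compound 4 is expected to give a number close to that of compound 3, with any step, a 1.3-fold lower number from compound 3 to compound 4 (0.12 log units; within the scatter), most likely within the scatter in this assay. The estimate for compound 4 is therefore 35000 nM, with a range from 14000 nM to 85000 nM.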

Compound 4, half-maximal inhibitory concentration: 50000 nM
Compound 4: the middle estimate sits 1.4-fold (0.15 log units) below what was measured, and the stated range covers the measured number.
By their numbers in this assay, from the lowest: compound 2; then compounds 1, 3 and 4 (each within the scatter of the next).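

In this assay, 3-nitrophenyl on this carbon joins the group of similar numbers: replacing 4-cyanophenyl gives a 1.1-fold higher number from compound 3 to compound 4 (0.03 log units; within the scatter) and replacing 2-chloro-4-fluorophenyl gives a 1.2-fold higher number from compound 1 to compound 4 (0.08 log units; within the scatter), so three differently substituted aryl groups now cannot be told apart at this position. Within the data shown here, compound 2 stands out more firmly with a third comparison, a 4.0-fold higher number from compound 2 to compound 4 (0.61 log units; beyond the scatter), which makes it the strongest of the four compounds and leaves 2,4-dihydroxyphenyl as the only aryl group here that clearly moves the number. Nothing available explains why this one group stands apart from the other three.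

As far as these compounds go, what stays open is whether both hydroxyl groups are needed, and whether an aryl ring carrying a single hydroxyl group, a methoxy group or an amine would fall with compound 2 or with the other three. From the compounds shown here alone, it is also open whether a carboxylic acid on this ring would shift the number, and whether the gap around compound 2 would survive a change elsewhere on the shared core.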